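Swapping Ethoxy for Methyl on a Shared Core

The source may hold more compounds than are shown below. What is called first, only, known or untested is meant among the compounds shown, and "the series" means these compounds.

Compound 1, `CCOc1ccc(NC(=O)c2cccc(/C=C3\CC(=O)N(c4ccccc4)C3=O)c2)cc1`: in an ADME assay on HCT-116 cells (Homo sapiens) for cytotoxicity, read by MTT assay, with a stated time of 72 h (a lower number here means a stronger inhibitor, a higher number a weaker inhibitor), compound 1 gives 84800 nM.
Compound 2, `CCc1cccc(NC(=O)c2cccc(/C=C3\CC(=O)N(Cc4ccccc4)C3=O)c2)c1`: in this assay compound 2 gives 80600 nM.
Compound 3, `CCCCCN1C(=O)C/C(=C\c2cccc(C(=O)NCCCC)c2)C1=O`: in this assay compound 3 reaches only a limit, > 100000 nM.

Of the two compounds with a number, compound 1 has the highest one, but compound 2 lies within the usual scatter of it, so the two cannot be told apart. Compound 3 gives a limit rather than a number; the limit of > 100000 nM in this assay, at which 1 of the 3 values shown sits, tells where that limit sits.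

Compound 4, `Cc1ccc(NC(=O)c2cccc(/C=C3\CC(=O)N(c4ccccc4)C3=O)c2)cc1`, differs from compound 1 in a single place: methyl in place of ethoxy on an aromatic carbon. Going by the values given here, no step between two measured compounds is available to guide how large such a change is, so the expectation rests on compound 1 alone. The expected step, a 1.0-fold higher number from compound 1 to compound 4 (0.00 log units; within the scatter), is small, no larger than the scatter in either direction. Compound 4 is therefore estimated at 85000 nM, between 40000 nM and 180000 nM. Because compound 1 gives 84800 nM, compound 4 is expected to return a similarly high number.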

Compound 4, half-maximal inhibitory concentration: > 100000 nM
Compound 4 gave a limit, no number; the forecaster's own chance of this, stated with the estimate: 35%; middle value at least 1.1-fold (0.07 log units) away from the limit.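

Methyl in place of ethoxy, on the aromatic carbon para to a large group, gives the first measured step on this shared core: an at least 1.1-fold higher number from compound 1 to compound 4 (0.07 log units; that floor lies within the scatter). That step is only a floor, so the result does not show whether this change moves the number by a little or by a lot, but it does show that the shorter group gives no measurable gain in this assay. Compound 4 gives a limit rather than a number, and the same limit now appears twice in the series: the limit of > 100000 nM in this assay, at which 2 of the 4 values shown sit.

On these data alone, the true size of the step from ethoxy to methyl remains open. Also open, as far as these compounds go, is whether an amine, a carboxylic acid or a longer chain in this place would bring the number down to where a real value can be read.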